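The source may report more compounds than this note shows. Statements on the series, on what has been measured and on what is new or still open speak of the compounds shown alone.

The shared core of this study carries two amide groups and a benzyl-type group on its aromatic nitrogen. Compound 1 `CNC(=O)c1cc(C(=O)NC2CC2)cn(Cc2ccc3nc[nH]c3c2)c1=O` is the starting point of the step followed here. In a physicochemical assay for solubility (on this read-out lower numbers stand for lower solubility and higher numbers for higher solubility), compound 1 gives a limit of the assay, >= 163 ug/mL. Compound 2 `CNC(=O)c1cc(C(=O)NCC(C)C)cn(Cc2ccccc2)c1=O` gives 43 ug/mL in this assay. Compound 3 `CNC(=O)c1cc(C(=O)NCCOC)cn(Cc2ccccc2)c1=O` gives a limit of the assay in this assay, >= 164 ug/mL. Among the compounds with values here, the one measured step, an at least 3.8-fold higher number from compound 2 to compound 3 (0.58 log units; beyond the scatter), concerns the chain on the amide-type nitrogen and ends at a limit (the limit of >= 164 ug/mL in this assay, at which 1 of the 3 values shown sits). Compound 4 `CNC(=O)c1cc(C(=O)NC2CC2)cn(Cc2cccc3c2CCN3)c1=O` differs from compound 1 at a different place: 2,3-dihydro-1H-indol-4-yl in place of 1H-benzimidazol-6-yl on a saturated chain carbon bound to an aromatic nitrogen. Within the data shown here, no measured step touches this place, so the measured steps give no guidance on direction for this change. Compound 1 itself stands at a limit (the limit of >= 163 ug/mL in this assay, at which 1 of the 3 values shown sits). The chemist expects a step of an at least 1.3-fold lower number from compound 1 to compound 4 (0.13 log units; that floor lies within the scatter) for compound 4, one that stays within the usual scatter. Compound 4 is therefore expected to give about 120 ug/mL in this assay, in a range from 40 ug/mL to 200 ug/mL.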

Compound 4, solubility: >= 184 ug/mL
Compound 4 was reported as a limit (the forecaster's own chance of this, stated with the estimate: 40%); middle value at least 1.5-fold (0.18 log units) from the limit.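

Within the data shown here, compound 1 and compound 4 are both reported as limits in this assay, so no step between them can be read. The compounds shown leave open how 2,3-dihydro-1H-indol-4-yl and 1H-benzimidazol-6-yl compare in this assay on a saturated chain carbon bound to an aromatic nitrogen.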